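Benzyl amide on the shared core: an expected cytotoxicity

The source may report more compounds than this note shows. Statements on the series, on what has been measured and on what is new or still open speak of the compounds shown alone.

Measured compounds:
compound 1 `CCNC(=O)Cn1nc(N)c2c(C(F)(F)F)cc(-c3ccccc3)nc21` — 21300 nM
compound 2 `NCCNC(=O)Cn1nc(N)c2c(C(F)(F)F)cc(-c3ccccc3)nc21` — 42900 nM
compound 3 `Nc1nn(CC(=O)NC2CC2)c2nc(-c3ccccc3)cc(C(F)(F)F)c12` — "not active" (no number reported) (no number reported)

In a functional assay on MCF7 cells (Homo sapiens) for cytotoxicity, read by MTT assay, with a stated time of 24 h (on this read-out higher numbers stand for weaker inhibition and lower numbers for stronger inhibition), compound 1 gives 21300 nM. Compound 2 stands at the highest of the two reported numbers; its nearest neighbour is compound 1, and the difference a 2.0-fold higher number from compound 1 to compound 2 (0.30 log units; within the scatter) lies within the scatter, so the two cannot be told apart. Compound 3 gave no number in this assay.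

Compound 4 `Nc1nn(CC(=O)NCc2ccccc2)c2nc(-c3ccccc3)cc(C(F)(F)F)c12` differs from compound 2 in one place: phenyl in place of aminomethyl on a saturated chain carbon bound to an amide-type nitrogen. Within the data shown here, no measured step bears directly on this change. Among the measured compounds shown here, the only measured step, a 2.0-fold higher number from compound 1 to compound 2 (0.30 log units; within the scatter), shows that a small change at the end of this chain left the number within the scatter. Compound 3, with a small ring at the same position, gave no number at all, which warns that the benzyl amide might also fall outside the measurable range.

For compound 4 the estimate in this assay is 28000 nM, with a range from 8000 nM to 100000 nM; the expected step of a 1.5-fold lower number from compound 2 to compound 4 (0.19 log units; within the scatter) is not expected to exceed the scatter.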

Compound 4, half-maximal inhibitory concentration: 16300 nM
Estimate against measurement, compound 4: 1.7-fold (0.23 log units) above; low and high end bracket the measured number.
By their numbers in this assay, from the lowest: compounds 4, 1 and 2 (each within the scatter of the next, the first and the last beyond it).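

In this assay, among these compounds, swapping the aminomethyl end of the chain for phenyl gives the first change at this position that clears the scatter, though only modestly: a 2.6-fold lower number from compound 2 to compound 4 (0.42 log units; beyond the scatter). The comparison with the ethyl amide reads differently, with a 1.3-fold lower number from compound 1 to compound 4 (0.12 log units; within the scatter), so compound 4 and compound 1 cannot be told apart, and the phenyl ring shows no measurable gain over a methyl at this place. Nothing measured here explains either step.

With compound 1 and compound 2 themselves inseparable, the shown compounds give only a narrow view of what this chain end can do. On these data alone, it remains open how a longer chain between the amide nitrogen and the phenyl ring, or a carboxylic acid at the chain end, would read in this assay.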